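A few compounds are considered here, and "the series" means these few. Any claim that something is new, unique, unknown or untested is made for them only; others in the source may bear on it.

Compound 1 `O=C(CCCCCCc1nc2ccccc2[nH]1)NO`: 2700 nM
Compound 2 `O=C(CCCCCCc1nc2ccc(F)cc2[nH]1)NO`: 1900 nM
Compound 3 `O=C(CCCCCCc1nc2ccc(Cl)cc2[nH]1)NO`: 320 nM
Compound 4 `O=C(CCCCCCc1nc2ccc(-c3ccccc3)cc2[nH]1)NO`: not yet measured

The three measured compounds share one core and were all tested in a functional assay on SK-OV-3 cells (Homo sapiens) for cytotoxicity; on this read-out higher numbers stand for weaker inhibition and lower numbers for stronger inhibition. Compound 3 stands lowest of the three numbers; compound 2 comes nearest and compound 1 furthest, as shown by a 5.9-fold lower number from compound 2 to compound 3 (0.77 log units; beyond the scatter) and an 8.4-fold lower number from compound 1 to compound 3 (0.93 log units; beyond the scatter). Compound 4 differs from compound 3 in a single place: phenyl in place of chloro on an aromatic carbon.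

Going by the values given here, no measured step swaps a halogen for a ring, so the guidance is indirect. Hydrogen to fluoro gave a 1.4-fold lower number from compound 1 to compound 2 (0.15 log units; within the scatter), hydrogen to chloro gave an 8.4-fold lower number from compound 1 to compound 3 (0.93 log units; beyond the scatter), and fluoro to chloro gave a 5.9-fold lower number from compound 2 to compound 3 (0.77 log units; beyond the scatter): at this place, the group with more heavy atoms has each time gone with the lower number, twice beyond the scatter. Phenyl brings more heavy atoms still, but as a ring rather than a single atom, and the series offers no direct test of that. A further modest lowering is expected, or none beyond the scatter. Compound 4 is therefore estimated at 200 nM, with a range from 60 nM to 800 nM. That estimate means an expected step of a 1.6-fold lower number from compound 3 to compound 4 (0.20 log units; within the scatter).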

Compound 4, half-maximal inhibitory concentration: 100 nM
The estimate for compound 4 lay 2.0-fold (0.30 log units) above the measured number, within the range that was stated.
By their numbers in this assay, from the lowest: compound 4; then compound 3; then compounds 2 and 1 (each within the scatter of the next).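

Replacing chloro with phenyl gives a 3.2-fold lower number from compound 3 to compound 4 (0.51 log units; beyond the scatter) in this assay and so shows that the trend towards lower numbers with more heavy atoms at this place does not stop at a single atom, but continues to a whole aromatic ring. Going by these compounds alone, measured from the smaller groups, the change produces the only large steps, with a 19-fold lower number from compound 2 to compound 4 (1.28 log units; beyond the scatter) and a 27-fold lower number from compound 1 to compound 4 (1.43 log units; beyond the scatter) as the two steps that place compound 4 lowest of the four. Nothing available here explains why the number falls at this place.

On these data alone, whether an aromatic ring is needed remains open, since a saturated cyclohexyl ring would separate the ring's size from its aromatic character. As far as these compounds go, it is also open how a phenyl ring carrying an amine or a carboxylic acid would behave.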